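The compounds below may be only part of what the source reports. "The series", "measured", "known", "first", "only" and "open" are said of these compounds alone.

Compound 2 `CNC(=O)CSc1nc2ccc(NC(=O)c3ccc([N+](=O)[O-])cc3)cc2s1` and compound 3 `O=C(CSc1nc2ccc(NC(=O)c3ccc([N+](=O)[O-])cc3)cc2s1)NCc1ccc(Cl)cc1` share one core and differ only by 4-chlorophenyl in place of hydrogen on a saturated chain carbon bound to an amide-type nitrogen. In a functional assay on MCF7 cells (Homo sapiens) for cytotoxicity, read by MTT assay, with a stated time of 48 h (on this read-out lower numbers stand for stronger inhibition and higher numbers for weaker inhibition), compound 2 reaches only the limit of the method, > 100000 nM. In this assay compound 3 likewise reaches only the limit, > 100000 nM. The step that the two limits leave unreadable from compound 2 to compound 3 therefore cannot be sized, because of the limit of > 100000 nM in this assay, at which 2 of the 3 values shown sit. Compound 1 `CNC(=O)CSc1nc2ccc(NC(=O)CCl)cc2s1` differs from compound 2 by chloromethyl in place of 4-nitrophenyl on a carbonyl carbon; in this assay compound 1 gives 5000 nM, which is an at least 20-fold lower number from compound 2 to compound 1 (1.30 log units; beyond the scatter). Compound 4 `O=C(CSc1nc2ccc(NC(=O)CCl)cc2s1)NCc1ccc(Cl)cc1` has not yet been measured; it carries the same change relative to compound 3, namely (chloromethyl in place of 4-nitrophenyl on a carbonyl carbon), at the same place. The expected step is an at least 20-fold lower number from compound 3 to compound 4 (1.30 log units; beyond the scatter), resting on the measured step of an at least 20-fold lower number from compound 2 to compound 1 (1.30 log units; beyond the scatter). Compound 4 is thus expected to give 5000 nM, probably between 1500 nM and 25000 nM.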

Compound 4, half-maximal inhibitory concentration: 4900 nM
Compound 4: the middle estimate sits 1.0-fold (0.01 log units) above what was measured; low and high end bracket the measured number.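

Carried onto the core of compound 3, the exchange of 4-nitrophenyl for chloromethyl on the carbonyl carbon again gives an at least 20-fold lower number from compound 3 to compound 4 (1.30 log units; beyond the scatter). With chloromethyl in place, the added 4-chlorophenyl gives a 1.0-fold lower number from compound 1 to compound 4 (0.01 log units; within the scatter), so in this assay this group leaves no readable mark on the result. The change thus points the same way on both cores, but this does not show that its size is the same on each: the same change on two cores in this assay, an at least 20-fold lower number (1.30 log units; beyond the scatter) from compound 2 to compound 1 and an at least 20-fold lower number (1.30 log units; beyond the scatter) from compound 3 to compound 4; the limit leaves it open whether they differ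

From the compounds shown here alone, only chloromethyl and 4-nitrophenyl stand on that carbonyl carbon here, so it remains open how a plain methyl, a longer chain or an amine there would read in this assay. Also open, going by these compounds, is whether a carboxylic acid in place of the 4-chlorophenyl would leave the result as unchanged.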